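This account rests on a few compounds, and the source may have more. Where it says the series, first, only, none or still open, it means among the compounds named here.

In a functional assay on MCF7 cells (Homo sapiens) for antiproliferative activity, read by sulforhodamine B assay, with a stated time of 48 h (a lower number here means a stronger inhibitor, a higher number a weaker inhibitor), compound 1 (`O=C1NCCN1c1ccc(S(=O)(=O)Nc2ccccc2)cc1`) gives 470 nM, the second highest of three numbers, and compound 2 (`O=C1NCCN1c1ccc(S(=O)(=O)Nc2ccc(F)c(F)c2)cc1`) gives 620 nM, within the scatter of it. Compound 3 (`Cc1cccc(NS(=O)(=O)c2ccc(N3CCNC3=O)cc2)c1C`) gives 230 nM. On the sulfonamide nitrogen, 3,4-difluorophenyl in place of phenyl gave a 1.3-fold higher number from compound 1 to compound 2 (0.12 log units; within the scatter), while 2,3-dimethylphenyl in place of phenyl gave a 2.0-fold lower number from compound 1 to compound 3 (0.31 log units; beyond the scatter). Compound 4 (`CCCCCc1ccc(NS(=O)(=O)c2ccc(N3CCNC3=O)cc2)cc1`) has pentyl in place of hydrogen on an aromatic carbon of compound 1: pentyl in place of hydrogen on an aromatic carbon. Neither measured step involves a chain, so they guide the size only loosely and suggest no firm direction. In this assay, no shift beyond the scatter is expected, and the expected step is a 1.3-fold higher number from compound 1 to compound 4 (0.11 log units; within the scatter). For compound 4 the estimated value is 600 nM, with an expected range of 150 nM to 2500 nM.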

Compound 4, half-maximal inhibitory concentration: > 1000 nM
Compound 4 gave a limit, no number; the forecaster's own chance of this, stated with the estimate: 5%; middle value at least 1.6-fold (0.22 log units) away from the limit.
By their numbers in this assay, from the lowest: compound 3; then compounds 1 and 2 (each within the scatter of the next). At a limit, above all of these: compound 4.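

In this assay, compound 4 gives only a limit, > 1000 nM, and not a number. Pentyl in place of hydrogen on an aromatic carbon, para to a large group, gave an at least 2.1-fold higher number from compound 1 to compound 4 (0.32 log units; beyond the scatter). Within the data shown here, the earlier steps involved no chain, so this is the first sign that a chain at this place can raise the number beyond the scatter. Going by these compounds, how far compound 4 lies past its limit stays open. So does whether a shorter chain such as ethyl, an amine or a carboxylic acid at this place would raise the number as well.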